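The compounds below may be only part of what the source reports. "The series", "measured", "known", "first", "only" and "open" are said of these compounds alone.

The study compares four acylthioureas built on a shared core that is either fully aromatic or partly saturated. Compound 1 `O=C(NC(=S)n1ccc2c(OCCCCCOc3ccc(Cl)cc3)cccc21)c1ccccc1` carries a benzoyl group and a 4-chlorophenoxypentyloxy side chain; in an ADME assay on Huh-7 cells (Homo sapiens) for cytotoxicity (on this read-out lower numbers stand for higher toxicity in this test and higher numbers for lower toxicity in this test), compound 1 gives 29500 nM. Compound 2 `O=C(NC(=S)N1CCc2c(OCc3ccccc3)cccc21)c1ccccc1` has a benzyloxy side chain on the partly saturated core. In this assay compound 2 reaches only the limit > 50000 nM. Compound 3 `O=C(NC(=S)N1CCc2c(OCCCCCOc3ccc(Cl)cc3)cccc21)Oc1ccccc1` combines the partly saturated core, the long side chain and a phenoxycarbonyl group on the thiourea. Compound 3 in this assay likewise gives only the limit > 50000 nM. Compound 3 therefore stands at the upper edge of what this assay resolves, and this is the common position among the three values (the limit of > 50000 nM in this assay, at which 2 of the 3 values shown sit). Compound 4 `O=C(NC(=S)N1CCc2c(OCCCCCOc3ccc(Cl)cc3)cccc21)c1ccc(C(F)(F)F)cc1` differs from compound 3 in one place: 4-(trifluoromethyl)phenyl in place of phenoxy on a carbonyl carbon. Among the measured compounds shown here, no measured pair in this set shows the effect of such a change. Compound 1, which also carries a benzoyl-type group, sits within the scatter of the limit, so a step toward lower numbers of at most the usual scatter is expected. Compound 4 is therefore expected to give about 35000 nM, within 15000 nM to 50000 nM. This estimate implies a step of an at least 1.4-fold lower number from compound 3 to compound 4 (0.15 log units; that floor lies within the scatter).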

Compound 4, half-maximal cytotoxic concentration: 32700 nM
Compound 4: middle estimate off by 1.1-fold (0.03 log units), on the high side; the range from low to high includes it.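

Among the compounds shown here, replacing phenoxy with 4-(trifluoromethyl)phenyl on a carbonyl carbon gives the only step in this set that can be read at this position in this assay: an at least 1.5-fold lower number from compound 3 to compound 4 (0.18 log units; that floor lies within the scatter). It shows that this change can be made with the long side chain and the partly saturated core kept in place, and that compound 4, unlike compound 3, gives a number and not a limit. The floor of the step lies within the scatter, so no real change is established, and the upper size of the step stays unknown because compound 3 sits at a limit of the assay: the limit of > 50000 nM in this assay, at which 2 of the 4 values shown sit.

The compounds shown leave open how much of the step comes from losing the oxygen of the phenoxy group and how much from the trifluoromethyl group, since no compound here pairs the plain phenyl group with compound 3 or compound 4 in one change. They also leave open how this assay would respond to a carboxylic acid or an amine in place of the trifluoromethyl group on this aromatic ring.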